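The source may hold more compounds than are shown below. What is called first, only, known or untested is meant among the compounds shown, and "the series" means these compounds.

Compound 2 `O=C(O)c1ccc(C=C2CCN(C(=O)C(C3CCCCC3)C3CCCCC3)CC2)c(F)c1` in an assay for inhibition of 3-oxo-5-alpha-steroid 4-dehydrogenase 1 (Homo sapiens), tested at 10 uM (on this read-out higher numbers stand for more inhibition at the one concentration tested (going by the name of the read-out) and lower numbers for less inhibition), gives 12%; compound 1 `O=C(O)Cc1ccc(C=C2CCN(C(=O)C(C3CCCCC3)C3CCCCC3)CC2)cc1` gives 6%, and the step of a number 6 percentage points higher from compound 1 to compound 2 (within the scatter) leaves the two indistinguishable. Compound 3 `O=C(O)Cc1ccc(C=C2CCN(C(=O)C(C3CCCCC3)C3CCCCC3)CC2)c(F)c1` differs from compound 2 by carboxymethyl in place of carboxy on an aromatic carbon. Among the compounds with values here, the only step that bears on it is the move from compound 1 to compound 2, which swapped carboxymethyl for carboxy together with the fluoro group and gave a number 6 percentage points higher from compound 1 to compound 2 (within the scatter); reversing the carboxy part alone is therefore expected to yield no step beyond the scatter, a number 4 percentage points lower from compound 2 to compound 3 (within the scatter). Compound 3 is expected at 8%, within -4% to 22%.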

Compound 3, a percentage reported as inhibition, at one concentration (the size of the read-out at that concentration, not a potency): 4%
Compound 3: the middle estimate sits 4 percentage points above what was measured, within the range that was stated.
By their numbers in this assay, from the lowest: compounds 3, 1 and 2 (each within the scatter of the next).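

In this assay the change of carboxy to carboxymethyl, now read with the fluoro group held constant, gives a number 8 percentage points lower from compound 2 to compound 3 (within the scatter) and so does not separate the two groups at this place. Fluoro in place of hydrogen, now read alone, gives a number 2 percentage points lower from compound 1 to compound 3 (within the scatter) and likewise does not separate the two. Nothing available speaks to the cause of either step.

Going by these compounds, whether an amine or a longer chain ending in a carboxylic acid at this place would give a step beyond the scatter stays open. So does whether chloro in place of fluoro would.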